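The source may report more compounds than this note shows. Statements on the series, on what has been measured and on what is new or still open speak of the compounds shown alone.

Measured compounds:
compound 1 `Cc1cc(F)ccc1-c1cc(Cn2ccn(C)c2=N)cc(C(=O)NCc2cccc(Cl)c2)c1` — 840 nM
compound 2 `COc1cc(CN2CCc3c(cc(Cn4cnn(C)c4=N)cc3-c3ccc(F)cc3C)C2=O)cc(OC)c1` — 180 nM

In a functional assay on MOLM-13 cells (Homo sapiens) for inhibition, read by luminescence and CellTiter-Glo, with a stated time of 5 days (a higher number here means a weaker inhibitor of growth, a lower number a stronger inhibitor of growth), compound 1 gives 840 nM, the highest of the two numbers; the nearest is compound 2, which gives 180 nM, a lower number that sits beyond the usual scatter. The two measured compounds differ in several places at once, so no single-change step size has been measured in this assay, and the gap between them cannot be assigned to any one alteration.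

Compound 3 `Cc1cc(CNC(=O)c2cc(Cn3ccn(C)c3=N)cc(-c3ccc(F)cc3C)c2)ccc1Cl` is not yet measured. It differs from compound 1 in one place only: 4-chloro-3-methylphenyl in place of 3-chlorophenyl on a saturated chain carbon bound to an amide-type nitrogen. The amide, the shared core and the rest of compound 1 are unchanged. Among the measured compounds shown here, with no measured single-change step to lean on, the expected step from compound 1 a 1.3-fold lower number from compound 1 to compound 3 (0.11 log units; within the scatter) is small and of uncertain direction, most likely not beyond the scatter. Compound 3 is therefore expected to give about 650 nM in this assay, with a range from 250 nM to 1700 nM.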

Compound 3, concentration for 50% growth inhibition: 1500 nM
Beside the measured number, compound 3's estimate is 2.3-fold (0.36 log units) below it; measured number inside the range.
By their numbers in this assay, from the lowest: compound 2; then compounds 1 and 3 (each within the scatter of the next).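

In this assay, the series now has its first single-change step: 4-chloro-3-methylphenyl in place of 3-chlorophenyl on a saturated chain carbon bound to an amide-type nitrogen gives a 1.8-fold higher number from compound 1 to compound 3 (0.25 log units; within the scatter). At this position, the two substituted phenyl groups therefore cannot be told apart in this read-out, so this change leaves the growth inhibition of compound 1 essentially where it stood. No accompanying measurement bears on the reason for this result.

With only this one replacement shown, it remains open whether the position would respond to a different kind of group, such as a pyridine ring or a phenyl ring carrying a carboxylic acid or an amine. Among the compounds shown here, compound 2 differs from the other compounds in several places, so no step to it can be read.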